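Cytotoxicity limits along a biaryl amide series

The source may report more compounds than this note shows. Statements on the series, on what has been measured and on what is new or still open speak of the compounds shown alone.

Compound 1, `CCOC(=O)CCCCCOc1cccc(CN(C(=O)c2ccc(-c3cccc(OCC(C)C)c3)cc2)C(C)C)c1`: in an ADME assay on HEK293 cells (Homo sapiens) for cytotoxicity, read by CellTiter-Glo and resazurin assay, with a stated time of 72 h (a lower number here means that less compound is needed, a higher number that more compound is needed for the effect), compound 1 gives > 26000 nM, which is a limit of the assay.
Compound 2, `CCOC(=O)CCCCCOc1cccc(CN(C(=O)c2ccc(-c3cccc(OC(C)C)c3)cc2)C(C)C)c1`: in this assay compound 2 gives > 26000 nM, again a limit.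
Compound 3, `CCOC(=O)CCCCCOc1cccc(CN(C(=O)c2ccc(-c3ccc(C(C)=O)s3)cc2)C(C)C)c1`: in this assay compound 3 gives > 26000 nM, also a limit.

Compound 3 therefore stands where every measured compound stands, at the limit of > 26000 nM in this assay, at which 3 of the 3 values shown sit. The steps that lead to it, a step that the two limits leave unreadable from compound 1 to compound 3 and a step that the two limits leave unreadable from compound 2 to compound 3, cannot be sized, and the same holds for a step that the two limits leave unreadable from compound 1 to compound 2.

Compound 4, `CCOC(=O)CCCCCOc1cccc(CN(C(=O)c2ccc(-c3cccc(OCC)c3)cc2)C(C)C)c1`, differs from compound 3 by 3-ethoxyphenyl in place of 5-acetylthiophen-2-yl on an aromatic carbon. This change runs the opposite way to the two steps that reach compound 3 from an alkoxyphenyl group, and both of those steps are unreadable, so no direction and no size can be taken from them. The only expectation that follows is that a step that the limit leaves unreadable from compound 3 to compound 4 would itself stay unreadable, with compound 4 most likely reported as a further limit. Compound 4 is accordingly estimated at 40000 nM in this assay, in the range 20000 nM to 120000 nM.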

Compound 4, half-maximal effective concentration: > 22300 nM
Compound 4: no number, only a limit; the forecaster's own chance of this, stated with the estimate: 85%; the middle value is on the limit's open side.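

In this assay compound 4 gives > 22300 nM, which is a limit of the assay and not a number. The steps to it from compound 1, compound 2 and compound 3 therefore cannot be read. The compounds shown leave open what concentration, if any, gives the half-maximal effect for any of them.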